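Swapping a thiocarbamate for a sulfonyl on the piperidine nitrogen

This account rests on a few compounds, and the source may have more. Where it says the series, first, only, none or still open, it means among the compounds named here.

Of the compounds shown here, three have been measured in a functional assay on CHO-K1 cells for agonist activity at Glucose-dependent insulinotropic receptor (Homo sapiens), read by a luciferase reporter, with a stated time of 5 h (a lower number here means that less compound is needed, a higher number that more compound is needed for the effect), all sharing the same core and differing only in the group attached to the amine nitrogen of the six-membered ring. Compound 1 `CC(C)(C)COC(=O)N1CCC(Oc2ncnc3c2CCN3c2ccc(S(C)(=O)=O)cc2F)CC1` gives 39.8 nM. Compound 2 `CSC(=O)N1CCC(Oc2ncnc3c2CCN3c2ccc(S(C)(=O)=O)cc2F)CC1` gives 251 nM. Compound 3 `CC(C)SC(=O)N1CCC(Oc2ncnc3c2CCN3c2ccc(S(C)(=O)=O)cc2F)CC1` gives 10 nM, the lowest number of the three; the step from compound 1 to compound 3 was a 4.0-fold lower number from compound 1 to compound 3 (0.60 log units; beyond the scatter), and from compound 2 to compound 3 it was a 25-fold lower number from compound 2 to compound 3 (1.40 log units; beyond the scatter).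

Compound 4 `CC(C)S(=O)(=O)N1CCC(Oc2ncnc3c2CCN3c2ccc(S(C)(=O)=O)cc2F)CC1` takes the next step: isopropylsulfonyl in place of (isopropylsulfanyl)carbonyl on an amine nitrogen in a ring. In this change the carbonyl is lost and the sulfur moves from a single-bonded position to a sulfonyl, while the isopropyl is kept. Among the compounds with values here, no measured pair shows this kind of exchange; the measured steps only show that a larger group on the sulfur helped (a 25-fold lower number from compound 2 to compound 3 (1.40 log units; beyond the scatter)) and that an isopropylsulfanyl carbonyl beat a neopentyloxy carbonyl (a 4.0-fold lower number from compound 1 to compound 3 (0.60 log units; beyond the scatter)). Since the isopropyl is retained but the carbonyl is not, a moderate rise in the number is expected for compound 4, estimated as an 8.0-fold higher number from compound 3 to compound 4 (0.90 log units; beyond the scatter) in this assay. Compound 4 is therefore expected to give about 80 nM, within a range of 12 nM to 500 nM.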

Compound 4, half-maximal effective concentration: 1260 nM
Beside the measured number, compound 4's estimate is 16-fold (1.20 log units) below it, and the stated range ends below it.
By their numbers in this assay, from the lowest: compound 3; then compound 1; then compound 2; then compound 4.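

In this assay, the isopropyl group alone does not secure a low number: with the isopropyl kept, exchanging the (isopropylsulfanyl)carbonyl for an isopropylsulfonyl gives a 130-fold higher number from compound 3 to compound 4 (2.10 log units; beyond the scatter), the largest step in this set. Compound 4 also loses to both other carbamate-type compounds, with a 5.0-fold higher number from compound 2 to compound 4 (0.70 log units; beyond the scatter) and a 32-fold higher number from compound 1 to compound 4 (1.50 log units; beyond the scatter), so at this amine nitrogen the way the group is attached matters at least as much as what sits at its end, even though the leaving and entering groups match in heavy atoms and hydrogen-bond acceptors. Nothing available here explains why this exchange costs so much.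

The compounds shown leave open whether the higher number follows from losing the carbonyl or from bringing in the sulfonyl, and an isobutyryl group, which keeps a carbonyl and an isopropyl without any sulfur, would help to separate the two. They also leave open whether the size of the group matters on a sulfonyl as it does on the sulfur of compound 2 and compound 3, which a methylsulfonyl or a cyclopropylsulfonyl group would test.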